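The compounds below may be only part of what the source reports. "The series", "measured", "known", "first", "only" and "open" are said of these compounds alone.

Measured series:
compound 1 `Cc1ccc(N(C)CC2CCC/C(=C\c3ccccc3)C2=O)cc1` gives 18.3%
compound 2 `Cc1ccc(/C=C2\CCCC(CN(C)c3ccc(C)cc3)C2=O)cc1` gives 27.6%
compound 3 `COc1ccc(C2(O)/C(=C/c3ccccc3)CCCC2CN(C)c2ccccc2)cc1` gives 26.5%

All three numbers come from a functional assay on the whole organism (Ear, strain Kunming) for inhibition, with Mus musculus as the target, with stated times of 1 h and 30 min, at a dose of 200 mg/kg by the oral route; on this read-out higher numbers stand for more inhibition at the one dose given (going by the name of the read-out) and lower numbers for less inhibition. The change from compound 1 to compound 2 is methyl in place of hydrogen on an aromatic carbon and it made a step of a number 9.3 percentage points higher from compound 1 to compound 2 (within the scatter), so the two numbers are not separated on this read-out. Compound 3 and compound 1 differ in more than one place; the difference between the two cores is not broken down here, and compound 3 and compound 2 give numbers within the scatter of each other.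

Compound 4 `COc1ccc(C2(O)/C(=C/c3ccc(C)cc3)CCCC2CN(C)c2ccccc2)cc1` is not yet measured. It differs from compound 3 by methyl in place of hydrogen on an aromatic carbon, the same change as from compound 1 to compound 2, at a place described in the same words. Going by the values given here, on the one precedent, the step from compound 3 to compound 4 is expected to be a number 4.5 percentage points higher from compound 3 to compound 4 (within the scatter), small and within the scatter, due to a number 9.3 percentage points higher from compound 1 to compound 2 (within the scatter) being itself within the scatter. Among the compounds with values here, compound 4 is therefore estimated at 31%, with the range 18% to 44% reflecting the single prior step and the usual spread of repeats.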

Compound 4, a percentage reported as inhibition, in the whole organism at one dose (the size of the read-out at that dose, not a potency): 16.3%
Beside the measured number, compound 4's estimate is 14.7 percentage points above it; the whole stated range lies above it.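

In this assay, going by these compounds alone, methyl in place of hydrogen on the core of compound 3 gives a number 10.2 percentage points lower from compound 3 to compound 4 (beyond the scatter), and set beside the same change on the core of compound 1 the outcome does not carry over: the same change on two cores in this assay, a number 9.3 percentage points higher (within the scatter) from compound 1 to compound 2 and a number 10.2 percentage points lower (beyond the scatter) from compound 3 to compound 4, 19.5 percentage points apart, beyond the scatter of two such steps On these two pairs, the step measured on one core is therefore no guide to the step on the other, so phenyl to 4-methylphenyl cannot be treated as a transferable change. Within the data shown here, this does not show which structural difference between the two cores separates the steps, since the cores differ in more than one place and each contributes only one pair, nor does a reading at a single dose show how either step would behave at other doses.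

From the compounds shown here alone, it remains open whether a chloro or an ethyl group at the same place on the ring would split between the two cores in the same way. Also open, going by these compounds, is whether a core changed in only one of its differing places would behave like the core of compound 1 or the core of compound 3.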